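The source may report more compounds than this note shows. Statements on the series, on what has been measured and on what is new or still open speak of the compounds shown alone.

Compound 1 `COc1ccccc1-n1c(Nc2nc(-c3ccc(Br)cc3)cs2)n[nH]c1=S` gives 300 mg/kg in a functional assay on the whole organism (strain Swiss albino) for inhibition, with Mus musculus as the target, with a stated time of 0.5 h; a higher number here means that more compound is needed for the effect, a lower number that less compound is needed.
Compound 2 `COc1ccccc1-n1c(Nc2nc(-c3ccc(Cl)cc3)cs2)n[nH]c1=S` gives 100 mg/kg in this assay.
Compound 3 `Cc1ccc(-n2c(Nc3nc(-c4ccc(Cl)cc4)cs3)n[nH]c2=S)cc1` gives 300 mg/kg in this assay.

All three share one core. Compound 1 and compound 2 differ in a single halogen: bromo in place of chloro on an aromatic carbon. That change gave a 3.0-fold higher number from compound 2 to compound 1 (0.48 log units; beyond the scatter). Compound 3 differs from compound 2 in the group on the aromatic nitrogen: 4-methylphenyl in place of 2-methoxyphenyl on an aromatic nitrogen. This gave a 3.0-fold higher number from compound 2 to compound 3 (0.48 log units; beyond the scatter). Compound 3 and compound 1 lie level at the digits read, so no order between them can be drawn.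

Compound 4 `Cc1ccc(-n2c(Nc3nc(-c4ccc(Br)cc4)cs3)n[nH]c2=S)cc1` has not yet been measured. It differs from compound 3 exactly as compound 1 differs from compound 2: bromo in place of chloro on an aromatic carbon. The two place descriptions agree word for word, so this is the same change, made here on the core of compound 3. Within the data shown here, only one earlier example of it exists, so the expectation rests on that single step. Because the earlier change gave a 3.0-fold higher number from compound 2 to compound 1 (0.48 log units; beyond the scatter), the step expected here is a 2.0-fold higher number from compound 3 to compound 4 (0.30 log units; within the scatter), with the caveat that a dose this high may be reported only as a limit. Compound 4 is therefore estimated at 600 mg/kg, likely between 300 mg/kg and 1000 mg/kg in this assay.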

Compound 4, minimum effective dose: 100 mg/kg
Estimate against measurement, compound 4: 6.0-fold (0.78 log units) above; measured number outside the range, below it.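

Bromo in place of chloro gave a 3.0-fold lower number from compound 3 to compound 4 (0.48 log units; beyond the scatter), the opposite direction to its earlier step, so in this assay this change does not carry over from one core to the other: the same change on two cores in this assay, a 3.0-fold higher number (0.48 log units; beyond the scatter) from compound 2 to compound 1 and a 3.0-fold lower number (0.48 log units; beyond the scatter) from compound 3 to compound 4, 9.0-fold (0.95 log units) apart, beyond the scatter of two such steps

The change on the aromatic nitrogen, 4-methylphenyl in place of 2-methoxyphenyl, behaves the same way, giving a 3.0-fold lower number from compound 1 to compound 4 (0.48 log units; beyond the scatter), so its two examples also disagree: the same change on two cores in this assay, a 3.0-fold higher number (0.48 log units; beyond the scatter) from compound 2 to compound 3 and a 3.0-fold lower number (0.48 log units; beyond the scatter) from compound 1 to compound 4, 9.0-fold (0.95 log units) apart, beyond the scatter of two such steps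

The effect of each change therefore depends on the other group present in these four compounds, but the data do not show why, and two examples of each change cannot predict the direction on a further core.

The compounds shown leave open whether fluoro or methyl in place of the chloro or bromo would follow either direction. Also open, as far as these compounds go, is how an unsubstituted phenyl or a longer chain on the aromatic nitrogen would behave alongside each halogen.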